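Exocyclic alkene core: swapping the six-membered heteroaromatic ring

This account rests on a few compounds, and the source may have more. Where it says the series, first, only, none or still open, it means among the compounds named here.

Measured compounds:
- compound 1, `O=C1O[C@H]([C@@H](O)Cn2ccc(NC(=O)c3ccccc3)nc2=O)C(OCc2ccccc2)=C1OCc1ccccc1`: 8820 nM
- compound 2, `O=C1O/C(=C\Cn2c(=O)[nH]c(=O)[nH]c2=O)C(OCc2ccccc2)=C1OCc1ccccc1`: 10 nM
- compound 3, `NC1(CCn2cc(F)c(=O)[nH]c2=O)OC(=O)C(OCc2ccccc2)=C1OCc1ccccc1`: 36200 nM

In an ADME assay on WI-38 cells (Homo sapiens) for inhibition, read by MTT assay, with a stated time of 72 h (on this read-out lower numbers stand for stronger inhibition and higher numbers for weaker inhibition), compound 2 gives 10 nM, the lowest number of the three. Compound 1 gives 8820 nM and compound 3 gives 36200 nM; both gaps from compound 2 lie well beyond the scatter, so compound 2 is the strongest inhibitor among the measured compounds. Going by the values given here, the three compounds differ in more than one place, so no single-change step between measured compounds is available to lean on.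

Compound 4, `O=C1O/C(=C\Cn2ncc(=O)[nH]c2=O)C(OCc2ccccc2)=C1OCc1ccccc1`, has not yet been measured in this assay. It differs from compound 2 in one place: a group of 8 heavy atoms (3 carbon, 3 nitrogen, 2 oxygen; one six-membered aromatic ring with 3 hetero atoms) in place of a group of 9 heavy atoms (3 carbon, 3 nitrogen, 3 oxygen; one six-membered aromatic ring with 3 hetero atoms), on a saturated chain carbon bound to a double-bonded chain carbon

Among the compounds with values here, with no measured step of this kind to guide the expectation, the account rests on compound 2 alone, whose value 10 nM is the anchor. A modest step toward weaker inhibition is expected, from compound 2 to compound 4 of a 5.0-fold higher number from compound 2 to compound 4 (0.70 log units; beyond the scatter), with wide uncertainty. Compound 4 is therefore expected to give about 50 nM in this assay, within a range of 5 nM to 500 nM.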

Compound 4, half-maximal inhibitory concentration: 24600 nM
Beside the measured number, compound 4's estimate is 490-fold (2.69 log units) below it, outside the stated range (above it).
By their numbers in this assay, from the lowest: compound 2; then compound 1; then compounds 4 and 3 (each within the scatter of the next).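

At the saturated chain carbon bound to a double-bonded chain carbon, the outcome in this assay depends sharply on which six-membered aromatic ring with 3 hetero atoms is attached: the group of 8 heavy atoms in place of the group of 9 heavy atoms gives a 2500-fold higher number from compound 2 to compound 4 (3.39 log units; beyond the scatter). This single change, which also goes from 2 hydrogen-bond donors to 1, is enough to remove the low number of compound 2, so that number cannot be credited to the shared core alone. Nothing available explains the size of this step.

The compounds shown leave open whether a ring carrying an amine or a carboxylic acid, or a longer chain at this place, would stay close to compound 2 or to compound 4. They also leave open whether this ring change would have a similar effect on the cores of compound 1 and compound 3.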